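Swapping a Cyclopentyl for an Ethoxyethyl on the Piperidine Amine

This account rests on a few compounds, and the source may have more. Where it says the series, first, only, none or still open, it means among the compounds named here.

Of the compounds shown here, three sharing one core have been measured in an assay on HEK293 cells for displacement of a labelled ligand from growth hormone secretagogue receptor type 1 (Homo sapiens), with a stated time of 60 min; on this read-out higher numbers stand for weaker inhibition and lower numbers for stronger inhibition. Compound 1 `Cc1ncccc1-c1nc2cn(-c3ccccc3)nc2c(=O)n1C[C@H]1CCCN(C[C@H]2CCCO2)C1` gives 190 nM. Compound 2 `COc1ccc(-n2cc3nc(-c4ccccc4C)n(CC4CCCN(C(C)C)C4)c(=O)c3n2)cc1` gives 7.3 nM. Compound 3 `COc1cccc(-n2cc3nc(-c4cccnc4C)n(C[C@H]4CCCN(CC5CCCC5)C4)c(=O)c3n2)c1` gives 12 nM, the second highest of the three numbers; its value and that of compound 2 sit within the usual scatter of each other, while compound 1 stands well apart, beyond the scatter.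

Compound 4 `CCO[C@H](C)CN1CCC[C@H](Cn2c(-c3cccnc3C)nc3cn(-c4cccc(OC)c4)nc3c2=O)C1` has not yet been measured. It differs from compound 3 in one place: 1-ethoxyethyl in place of cyclopentyl on a saturated chain carbon bound to an amine nitrogen in a ring. Among the compounds with values here, no single-change step between measured compounds is available to calibrate this swap. Compound 1, whose amine nitrogen also carries a substituent holding an oxygen, gives the weakest number, but it differs from compound 3 in more than one place, so it is at best a loose hint.

The change from compound 3 to compound 4 is expected to cost some potency, roughly a 2.1-fold higher number from compound 3 to compound 4 (0.32 log units; beyond the scatter), a step that may not clear the scatter. Compound 4 is therefore estimated at 25 nM, within a range from 8 nM to 80 nM.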

Compound 4, half-maximal inhibitory concentration: 40 nM
Estimate against measurement, compound 4: 1.6-fold (0.20 log units) below; the measured number falls inside the stated range.
By their numbers in this assay, from the lowest: compounds 2 and 3 (each within the scatter of the next); then compound 4; then compound 1.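

In this assay, within the data shown here, this change gives the first single-change reading at this place: a 3.3-fold higher number from compound 3 to compound 4 (0.52 log units; beyond the scatter) is a modest step, but it lies beyond the scatter. Although cyclopentyl and 1-ethoxyethyl have the same count of heavy atoms, matching that count on a saturated chain carbon bound to an amine nitrogen in a ring does not keep the number of compound 3 unchanged. No measurement shown gives a reason for this step.

The swap removes a ring and adds an oxygen and a defined stereocentre all at once, so the compounds shown cannot separate these changes. As far as these compounds go, how a pentyl chain, with neither ring nor oxygen, would read at this place remains open, as does the opposite configuration of the 1-ethoxyethyl group.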